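Cytotoxicity Step from Trifluoromethoxy to a Cyanofluorophenyl Group

A few compounds are considered here, and "the series" means these few. Any claim that something is new, unique, unknown or untested is made for them only; others in the source may bear on it.

Measured compounds:
compound 1 `Cc1cc(F)ccc1Cc1c(C)c2ccc(OCC(O)CN3CCC(C(N)=O)CC3)cc2oc1=O` — > 100000 nM
compound 2 `Cc1c(Cc2ccc(F)cc2F)c(=O)oc2cc(OCC(O)CN3CCC(C(N)=O)CC3)ccc12` — > 100000 nM
compound 3 `Cc1c(Cc2ccc(OC(F)(F)F)cc2)c(=O)oc2cc(OCC(O)CN3CCC(C(N)=O)CC3)ccc12` — 68200 nM

In an ADME assay on A549 cells (Homo sapiens) for cytotoxicity, read by CellTiter-Glo (a lower number here means that less compound is tolerated, a higher number that more compound is tolerated), compound 1 gives > 100000 nM, which is a limit of the assay and not a number. Compound 2 likewise reaches only a limit, > 100000 nM. Compound 3 stands as the only number shown, at 68200 nM. The two further values, those of compound 1 and compound 2, are limits of the assay (the limit of > 100000 nM in this assay, at which 2 of the 3 values shown sit). The step of an at least 1.4-fold lower number from compound 1 to compound 3 (0.16 log units; that floor lies within the scatter) and the step of an at least 1.4-fold lower number from compound 2 to compound 3 (0.16 log units; that floor lies within the scatter) are therefore floors only, and the step that the two limits leave unreadable from compound 1 to compound 2 cannot be read.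

Compound 4 `Cc1c(Cc2ccc(-c3ccc(C#N)c(F)c3)cc2)c(=O)oc2cc(OCC(O)CN3CCC(C(N)=O)CC3)ccc12` follows from compound 3 by 4-cyano-3-fluorophenyl in place of trifluoromethoxy on an aromatic carbon. Both readable steps touch the same benzylic aryl group and each gave an at least small lowering toward compound 3, but neither reaches beyond the scatter, so no direction beyond the scatter can be drawn from them. For compound 4 a modest lowering is expected, a 1.7-fold lower number from compound 3 to compound 4 (0.23 log units; within the scatter), with a fair chance the assay again reports only a limit. The estimate for compound 4 in this assay is 40000 nM, between 12000 nM and 100000 nM.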

Compound 4, half-maximal cytotoxic concentration: 29100 nM
For compound 4 the middle estimate is 1.4-fold (0.14 log units) above the measured one; the range from low to high includes it.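

In this assay, putting 4-cyano-3-fluorophenyl in place of trifluoromethoxy gives a 2.3-fold lower number from compound 3 to compound 4 (0.37 log units; beyond the scatter). Among these compounds, this is the first step with a size that can be read from two numbers and that lies beyond the scatter, whereas the earlier steps were floors within the scatter or could not be read. It shows that this place, on an aromatic carbon para to a large group, takes a further six-membered aromatic ring with less compound tolerated, though only modestly so.

As far as these compounds go, whether the step belongs to the added ring itself or to its nitrile and fluorine stays open, and a plain phenyl or a phenyl bearing a carboxylic acid at this place would bear on that. How far compound 1 and compound 2 lie from the others also stays open, as each remains a limit of the assay: the limit of > 100000 nM in this assay, at which 2 of the 4 values shown sit.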